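The source may report more compounds than this note shows. Statements on the series, on what has been measured and on what is new or still open speak of the compounds shown alone.

Measured so far in an ADME assay on the whole organism (plasma) for pharmacokinetics, with Cynomolgus monkey (Macaca fascicularis) as the target, at a dose of 3 mg/kg by the oral route; on this read-out higher numbers stand for higher exposure at the dose given and lower numbers for lower exposure:
Compound 1 `O=CN(O)C(CS(=O)(=O)c1ccc(Oc2ccc(OC(F)(F)F)cc2)cc1)C1CCC2(CC1)OCCO2`: 15300 ng.h/mL
Compound 2 `C[C@@H]1OC(C)(C)O[C@H]1C(CS(=O)(=O)c1ccc(Oc2ccc(OC(F)(F)F)cc2)cc1)N(O)C=O`: 10900 ng.h/mL

On these numbers, compound 2 cannot be told apart from compound 1, since the two values lie within the usual scatter of each other. Still unmeasured is compound 3 `CC1(C)OC[C@H](CC(CS(=O)(=O)c2ccc(Oc3ccc(OC(F)(F)F)cc3)cc2)N(O)C=O)O1`, which has the same atoms as compound 2, joined differently. The change is (2,2-dimethyl-1,3-dioxolan-4-yl)methyl in place of 2,2,5-trimethyl-1,3-dioxolan-4-yl on a saturated chain carbon bound to an amide-type nitrogen and a saturated chain carbon. The new group, (2,2-dimethyl-1,3-dioxolan-4-yl)methyl, sits on the same saturated chain carbon bound to an amide-type nitrogen and a saturated chain carbon.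

Among the compounds with values here, only one measured step bears on this. It exchanged a different group at that same place, and a 1.4-fold lower number from compound 1 to compound 2 (0.15 log units; within the scatter) stayed within the scatter. Within the data shown here, one step is thin evidence, and no measurement yet tests this particular rearrangement. With that caution, no change beyond the scatter is expected in this assay. The estimated step is a 1.1-fold lower number from compound 2 to compound 3 (0.04 log units; within the scatter), which is no real difference. For compound 3 the expected value is 10000 ng.h/mL, with an estimated range of 4000 ng.h/mL to 25000 ng.h/mL.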

Compound 3, area under the concentration-time curve: 1040 ng.h/mL
Beside the measured number, compound 3's estimate is 9.6-fold (0.98 log units) above it; measured number below the stated range.
By their numbers in this assay, from the lowest: compound 3; then compounds 2 and 1 (each within the scatter of the next).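

In this assay, the saturated chain carbon bound to an amide-type nitrogen and a saturated chain carbon now proves to be a place where the exposure can shift sharply: the earlier exchange here stayed within the scatter, yet merely rejoining the same atoms gives a 10-fold lower number from compound 2 to compound 3 (1.02 log units; beyond the scatter). The heavy atoms, hydrogen-bond donors and hydrogen-bond acceptors counted for 2,2,5-trimethyl-1,3-dioxolan-4-yl and (2,2-dimethyl-1,3-dioxolan-4-yl)methyl are the same and neither group has a net charge, so these counts alone do not separate a high number from a low one here; the groups differ in how their atoms are joined and in having 2 defined stereocentres against 1. The new group also stands well apart from the ring-bearing group of the first compound, with a 15-fold lower number from compound 1 to compound 3 (1.17 log units; beyond the scatter).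

The compounds shown leave open whether the other stereoisomer of (2,2-dimethyl-1,3-dioxolan-4-yl)methyl would read the same, and how a 1,3-dioxane ring or an open-chain diol at this place would compare. Nothing available here offers an explanation for this drop in exposure.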